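The source may report more compounds than this note shows. Statements on the series, on what has been measured and on what is new or still open speak of the compounds shown alone.

Measured so far in a functional assay on the whole organism for inhibition, with Cavia porcellus as the target; on this read-out lower numbers stand for an effect already at smaller amounts and higher numbers for an effect only at larger amounts of compound:
- compound 1 `COc1ccccc1OCC1SCCN1C(=O)CN`: 57 mg/kg
- compound 2 `C=CC(=O)N1CCSC1COc1ccccc1OC`: 74 mg/kg
- compound 3 `CCOC(=O)CCC(=O)N1CCSC1COc1ccccc1OC`: 24 mg/kg

Compound 3 has the lowest number of the three, and its steps to both other compounds lie beyond the scatter. Compound 1 and compound 2 cannot be separated, as a 1.3-fold higher number from compound 1 to compound 2 (0.11 log units; within the scatter) shows.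

The next step leads to compound 4 `CNC(=O)CC(=O)N1CCSC1COc1ccccc1OC`: methylcarbamoyl in place of (ethoxycarbonyl)methyl on a saturated chain carbon bound to a carbonyl carbon. In words, methylcarbamoyl stands in place of (ethoxycarbonyl)methyl on a saturated chain carbon bound to a carbonyl carbon. Among the compounds with values here, two measured steps bear on this place, a 2.4-fold lower number from compound 1 to compound 3 (0.38 log units; beyond the scatter) and a 3.1-fold lower number from compound 2 to compound 3 (0.49 log units; beyond the scatter). Both are modest, and both arrive at the compound that carries the ethoxycarbonyl group. Within the data shown here, compound 4 loses that group, and no measured compound carries methylcarbamoyl, so the transfer is uncertain. A partial return towards the numbers of compound 1 and compound 2 is the working expectation in this assay, which means a modest move to a higher number rather than a further fall. The expected change is a 2.1-fold higher number from compound 3 to compound 4 (0.32 log units; beyond the scatter). For compound 4 the estimated value is 50 mg/kg, with an expected range from 22 mg/kg to 110 mg/kg.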

Compound 4, dose for half-maximal effect: 21 mg/kg
Estimate against measurement, compound 4: 2.4-fold (0.38 log units) above; the measured number lies below the stated range.
By their numbers in this assay, from the lowest: compounds 4 and 3 (each within the scatter of the next); then compounds 1 and 2 (each within the scatter of the next).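

In this assay, the ester is not needed at this place: methylcarbamoyl in place of (ethoxycarbonyl)methyl on a saturated chain carbon bound to a carbonyl carbon gives a 1.1-fold lower number from compound 3 to compound 4 (0.06 log units; within the scatter), even though the group that enters has 4 heavy atoms and 1 hydrogen-bond donor, while the group that leaves has 6 heavy atoms and 0 hydrogen-bond donors. The advantage over the other two compounds therefore survives the exchange, with a 2.7-fold lower number from compound 1 to compound 4 (0.43 log units; beyond the scatter) and a 3.5-fold lower number from compound 2 to compound 4 (0.55 log units; beyond the scatter), both modest. Compound 3 and compound 4 share a second carbonyl in the chain on the carbonyl carbon, which compound 1 and compound 2 lack, but two compounds on each side only describe this split and do not establish a rule.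

No accompanying measurement gives a reason for these numbers. Still open, from the compounds shown here alone, is whether the second carbonyl matters at all, and whether a carboxylic acid, an unsubstituted amide, a dimethylamide without the amide hydrogen or a longer chain at this place would stay with compound 3 and compound 4 or return to the level of compound 1 and compound 2.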